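Chain double bond on compound 1: expected step

A few compounds are considered here, and "the series" means these few. Any claim that something is new, unique, unknown or untested is made for them only; others in the source may bear on it.

In a functional assay on the whole organism (strain Hartley) for inhibition, with Cavia porcellus as the target, with stated times of 15 min and 2 min (on this read-out higher numbers stand for an effect only at larger amounts of compound and lower numbers for an effect already at smaller amounts), compound 1 (`CCCCC1([C@@H](O)/C=C/C2[C@H](O)CC(=O)[C@@H]2CCCCCCC(=O)O)CCC1`) gives 0.017 mg/kg and lies within the scatter of compound 2 (`CCCCC1([C@@H](O)/C=C/C2CCC(=O)[C@@H]2CCCCCCC(=O)O)CCC1`) at 0.0139 mg/kg on this read-out. Compound 3 (`CCCCC1([C@H](O)/C=C/C2CCC(=O)[C@@H]2CCCCSCC(=O)O)CCC1`) gives a clearly higher number at 0.0912 mg/kg and differs from compound 1 in more than one place, so it does not isolate a change in the chain.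

Compound 4 (`CCCCC1([C@@H](O)/C=C/C2[C@H](O)CC(=O)[C@@H]2C/C=C\CCCC(=O)O)CCC1`) keeps the rest of compound 1 and carries 5-carboxypent-1-en-1-yl in place of 5-carboxypentyl on a saturated chain carbon bound to a saturated ring carbon in the chain. Within the data shown here, no measured step covers this change on its own. Among the measured compounds shown here, the only single-place step (a 1.2-fold lower number from compound 1 to compound 2 (0.09 log units; within the scatter)) puts hydrogen in place of hydroxy on a saturated ring carbon, away from the chain, and serves as a loose guide to size only. No shift beyond the scatter is therefore expected, though with little direct support. In this assay the estimated step is a 1.2-fold higher number from compound 1 to compound 4 (0.07 log units; within the scatter) and it carries wide uncertainty. For compound 4 the expected value is 0.02 mg/kg with an estimated range of 0.007 mg/kg to 0.06 mg/kg in this assay.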

Compound 4, dose for half-maximal effect: 0.0484 mg/kg
Estimate against measurement, compound 4: 2.4-fold (0.38 log units) below; the range from low to high includes it.
By their numbers in this assay, from the lowest: compounds 2 and 1 (each within the scatter of the next); then compounds 4 and 3 (each within the scatter of the next).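

In this assay, among these compounds, the swap of 5-carboxypentyl for 5-carboxypent-1-en-1-yl gives a 2.8-fold higher number from compound 1 to compound 4 (0.45 log units; beyond the scatter) and is the only single-place step so far that lies beyond the scatter. The other such step, a 1.2-fold lower number from compound 1 to compound 2 (0.09 log units; within the scatter) on removal of the ring hydroxy, stays within it, so a number that held there does move at this saturated chain carbon, although the heavy atoms of the chain are unchanged in count and an added double bond is the difference. Nothing available speaks to the reason for this shift.

On these data alone, whether the same double bond moves the number to a similar extent on the core of compound 2 remains open. Also open, as far as these compounds go, is how a longer chain, or a primary amide in place of the terminal carboxylic acid, would read at this place.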